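Methoxy in place of methyl in compound 3

A few compounds are considered here, and "the series" means these few. Any claim that something is new, unique, unknown or untested is made for them only; others in the source may bear on it.

In a functional assay on KB cells (Homo sapiens) for antiproliferative activity, read by sulforhodamine B assay, with a stated time of 3 days (on this read-out higher numbers stand for an effect only at larger amounts of compound and lower numbers for an effect already at smaller amounts), compound 1 `CCC1=C(O)c2c(oc(-c3ccccc3OC)cc2=O)C(CC)(CC)C1=O` gives 40.8 uM and compound 2 `CCC1=C(O)c2c(oc(-c3ccc(C)c(C)c3)cc2=O)C(CC)(CC)C1=O` gives 35.5 uM. These two numbers lie within the usual scatter of each other, so compound 2 stands level with compound 1. Compound 3 `CCC1=C(O)c2c(oc(-c3ccc(OC)c(C)c3)cc2=O)C(CC)(CC)C1=O` carries methoxy in place of methyl on an aromatic carbon. Going by the values given here, the only measured step, a 1.1-fold lower number from compound 1 to compound 2 (0.06 log units; within the scatter), also exchanged groups on an aromatic carbon and stayed within the scatter, so no step beyond the scatter is expected in this assay. The expected step is a 1.1-fold lower number from compound 2 to compound 3 (0.03 log units; within the scatter). Compound 3 is estimated at 33 uM, with an expected range of 15 uM to 70 uM.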

Compound 3, concentration for half-maximal effect: 28.5 uM
The estimate for compound 3 lay 1.2-fold (0.06 log units) above the measured number, within the range that was stated.
By their numbers in this assay, from the lowest: compounds 3, 2 and 1 (each within the scatter of the next).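

Methoxy in place of methyl on this aromatic carbon, ortho to a methyl group and para to a large group, gives a 1.2-fold lower number from compound 2 to compound 3 (0.10 log units; within the scatter) in this assay, so adding an oxygen here brings no step beyond the scatter. The larger exchange, 4-methoxy-3-methylphenyl in place of 2-methoxyphenyl, gives a 1.4-fold lower number from compound 1 to compound 3 (0.16 log units; within the scatter) and also stays level. No independent measurement is available to explain these results. Still open, from the compounds shown here alone, is whether an amine, a carboxylic acid or a longer chain at this position would move the number beyond the scatter.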